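A few compounds are considered here, and "the series" means these few. Any claim that something is new, unique, unknown or untested is made for them only; others in the source may bear on it.

Three measured compounds share one core, and a fourth built on the same core awaits measurement. Compound 1 `CC(C)(C)c1cc(CNC(=O)Nc2cccc3[nH]ncc23)n(-c2ccc(C(F)(F)F)cc2)n1` is the reference. In an assay on CHO-K1 cells for antagonist activity at transient receptor potential cation channel subfamily V member 1 (Homo sapiens), read by FLIPR and calcium flux, with a stated time of 6 min (on this read-out higher numbers stand for weaker inhibition and lower numbers for stronger inhibition), compound 1 gives 19.6 nM. Compound 2 `CC(C)(C)c1ccc(-n2nc(C(C)(C)C)cc2CNC(=O)Nc2cccc3[nH]ncc23)cc1` differs from compound 1 in a single place: tert-butyl in place of trifluoromethyl on an aromatic carbon. That change made a 2.0-fold higher number from compound 1 to compound 2 (0.31 log units; beyond the scatter), so that compound 2 gives 40 nM in this assay. Compound 3 `Cn1ncc2c(NC(=O)NCc3cc(C(C)(C)C)nn3-c3ccc(C(F)(F)F)cc3)cccc21` differs from compound 1 elsewhere: methyl in place of hydrogen on an aromatic nitrogen. Here the step was a 1.6-fold lower number from compound 1 to compound 3 (0.20 log units; within the scatter), and compound 3 gives 12.4 nM in this assay.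

Compound 4 `Cn1ncc2c(NC(=O)NCc3cc(C(C)(C)C)nn3-c3ccc(C(C)(C)C)cc3)cccc21` differs from compound 3 in exactly one place: tert-butyl in place of trifluoromethyl on an aromatic carbon. Within the data shown here, this is the same change as the one from compound 1 to compound 2, and the description of its surroundings reads the same word for word in both pairs. Among the measured compounds shown here, the only difference between the two cores on which the change is made is the one already described between compound 1 and compound 3, a methyl in place of hydrogen on an aromatic nitrogen.

The same change gave a 2.0-fold higher number from compound 1 to compound 2 (0.31 log units; beyond the scatter), and compound 3 stands at 12.4 nM. On that basis compound 4 is expected to show a 2.0-fold higher number from compound 3 to compound 4 (0.30 log units; within the scatter). For the measured compounds named here, the estimate for compound 4 in this assay is 25 nM, with a range from 12 nM to 50 nM, kept wide since only a single earlier example of this change is known.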

Compound 4, inhibition constant: 46.3 nM
For compound 4 the middle estimate is 1.9-fold (0.27 log units) below the measured one; measured number inside the range.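

In this assay, putting tert-butyl in place of trifluoromethyl gave a 3.7-fold higher number from compound 3 to compound 4 (0.57 log units; beyond the scatter), so the change pointed the same way on both cores, and the two steps are no further apart than repeated measurements would allow: the same change on two cores in this assay, a 2.0-fold higher number (0.31 log units; beyond the scatter) from compound 1 to compound 2 and a 3.7-fold higher number (0.57 log units; beyond the scatter) from compound 3 to compound 4, 1.8-fold (0.26 log units) apart, within the scatter of two such steps. Methyl in place of hydrogen on the aromatic nitrogen, now seen on the tert-butyl compounds, gave a 1.2-fold higher number from compound 2 to compound 4 (0.06 log units; within the scatter), and this step also matches its earlier counterpart, with neither step lying beyond the scatter: the same change on two cores in this assay, a 1.6-fold lower number (0.20 log units; within the scatter) from compound 1 to compound 3 and a 1.2-fold higher number (0.06 log units; within the scatter) from compound 2 to compound 4, 1.8-fold (0.26 log units) apart, within the scatter of two such steps. Within these four compounds, then, each change carried over from one core to the other, but this rests on a single pair of steps for each change, so it does not show that the same would hold on further cores in the series, nor does it explain why either change has the size it has.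

The compounds shown leave open whether other groups in the same place on the phenyl ring, such as a chlorine atom, a nitrile or a methoxy group, would also give matching steps on both cores. They also leave open whether a longer chain on the aromatic nitrogen, such as ethyl or propyl, would stay within the scatter as methyl does.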